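A few compounds are considered here, and "the series" means these few. Any claim that something is new, unique, unknown or untested is made for them only; others in the source may bear on it.

Measured so far: compound 1 `CCCCNc1nc(N)nc(C)c1CCCN(CC)CC` gives 254 nM in an assay on HEK293 cells for agonist activity at Toll-like receptor 8 (Homo sapiens), read by spectrophotometry; a lower number here means that less compound is needed, a higher number that more compound is needed for the effect; compound 2 `CCCCNc1nc(N)nc(C)c1CCCN1CCCCC1` gives 133 nM.

Among the measured compounds shown here, compound 2 holds the lowest of the two numbers, yet the only step seen, a 1.9-fold lower number from compound 1 to compound 2 (0.28 log units; within the scatter), stays within the scatter, so the two compounds are not distinguished. Compound 3 `CCCCNc1nc(N)nc(C)c1CCC(C)(C)O` differs from compound 2 by 1-hydroxy-1-methylethyl in place of (piperidin-1-yl)methyl on a saturated chain carbon, two bonds along the chain from an aromatic carbon. For the measured compounds named here, no measured step bears on this change: the amine-to-amine swap says nothing about an alcohol-bearing shorter chain. A modest rise in the number is expected, a 3.0-fold higher number from compound 2 to compound 3 (0.48 log units; beyond the scatter), with wide uncertainty. Compound 3 is therefore estimated at 400 nM, within 100 nM to 2000 nM.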

Compound 3, half-maximal effective concentration: 3140 nM
Estimate against measurement, compound 3: 7.9-fold (0.89 log units) below, and the stated range ends below it.
By their numbers in this assay, from the lowest: compounds 2 and 1 (each within the scatter of the next); then compound 3.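

Swapping one amine for another left the number within the scatter, but leaving the amine series at this position matters far more: 1-hydroxy-1-methylethyl gives a 24-fold higher number from compound 2 to compound 3 (1.37 log units; beyond the scatter) when it replaces (piperidin-1-yl)methyl and a 12-fold higher number from compound 1 to compound 3 (1.09 log units; beyond the scatter) when it replaces (diethylamino)methyl. So this end of the chain tolerates two different amines, yet compound 3, which carries an alcohol there, needs much more compound for the effect. Nothing available here explains this rise. From the compounds shown here alone, because the amine leaves and the hydroxyl enters in a single change, their separate contributions remain open. A morpholin-4-yl group or a plain alkyl end on the same chain would help separate them.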